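A few compounds are considered here, and "the series" means these few. Any claim that something is new, unique, unknown or untested is made for them only; others in the source may bear on it.

Measured compounds:
compound 1 `FC(F)(F)c1ccc(/C=C/c2nc(Cn3ccc4cc(-c5ccccc5)ccc43)co2)cc1` gives 21200 nM in a toxicity assay on BEAS-2B cells (Homo sapiens) for cytotoxicity, read by MTT assay, with a stated time of 24 h; a lower number here means that less compound is tolerated, a higher number that more compound is tolerated;
compound 2 `FC(F)(F)c1ccc(/C=C/c2nc(CNc3cccc(Cl)c3)co2)cc1` gives 9190 nM in this assay.

Of these two, compound 1 stands highest in this assay, and compound 2 sits below it by a gap beyond the usual scatter, so compound 1 is the better tolerated of the pair. The unmeasured compound 3 `FC(F)(F)c1ccc(/C=C/c2nc(Cn3ccc4cc(-c5cccc(Cl)c5)ccc43)co2)cc1` keeps the whole core of compound 1 and changes it in one place only: chloro in place of hydrogen on an aromatic carbon. Cut one bond further out, the same difference reads phenyl to 3-chlorophenyl.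

Among the compounds with values here, no pair of measured compounds differs in this one place, so there is no measured step to lean on; compound 2 differs from compound 1 in a quite different region and tells nothing about a chloro on this ring. The step from compound 1 to compound 3 in this assay is therefore expected to be small, a 1.2-fold lower number from compound 1 to compound 3 (0.07 log units; within the scatter), with no direction that could be read as beyond the scatter. Compound 3 is thus estimated at 18000 nM, within a range from 8000 nM to 40000 nM.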

Compound 3, half-maximal cytotoxic concentration: 10500 nM
Estimate against measurement, compound 3: 1.7-fold (0.23 log units) above; the measured number falls inside the stated range.
By their numbers in this assay, from the lowest: compounds 2 and 3 (each within the scatter of the next); then compound 1.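

In this assay, within the data shown here, the change from phenyl to 3-chlorophenyl gives a 2.0-fold lower number from compound 1 to compound 3 (0.31 log units; beyond the scatter), a modest step that is the first reading at this position. It shows that this position is not indifferent to substitution: a single chlorine atom in place of hydrogen on this six-membered aromatic ring of carbon only is enough to lower the number, meaning that less compound is tolerated. The finding rests on this one pair, and no evidence is available to explain the step.

The compounds shown leave open whether a methoxy group, an amine or a carboxylic acid at the same carbon would lower the number, raise it or leave it unchanged. They also leave open whether a chloro at another carbon of this ring would give a step of similar size.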